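The source may hold more compounds than are shown below. What is called first, only, known or untested is meant among the compounds shown, and "the series" means these compounds.

Measured compounds:
- compound 1, `CN(C)/N=N\c1ccnc2cc(Br)ccc12`: -2.4%
- compound 2, `CN(C)/N=N\c1ccnc2cc(Cl)ccc12`: -16.3%
- compound 3, `CN(C)/N=N\c1ccnc2c(Br)cccc12`: 4.8%

All three were run in a toxicity assay on the whole organism (P388 cells) for cytotoxicity, with Mus musculus as the target, with a stated time of 9 days, at a dose of 30 mg/kg by the intraperitoneal route; a higher number here means a weaker effect of the compound at the dose given, a lower number a stronger effect. Compound 1 and compound 2 share a core and differ by chloro in place of bromo on an aromatic carbon. That change gave a number 13.9 percentage points lower from compound 1 to compound 2 (beyond the scatter). Compound 3 carries the same atoms as compound 1 joined differently; the difference between the two cores is not broken down here. Compound 3 and compound 1 sit within the scatter of each other in this assay, while compound 2 lies beyond it from both.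

Compound 4, `CN(C)/N=N\c1ccnc2c(Cl)cccc12`, has not been measured. It differs from compound 3 by chloro in place of bromo on an aromatic carbon. This is the same kind of change as that from compound 1 to compound 2, but not the same: there the place was meta to a fused ring and para to a fused ring, here it is ortho to a fused ring and meta to a fused ring. If the step repeats, compound 4 is expected to move by about a number 11.8 percentage points lower from compound 3 to compound 4 (beyond the scatter), resting on the step from compound 1 to compound 2 and on compound 3 at 4.8%. The estimate for compound 4 in this assay is -7%, expected between -22% and 8%.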

Compound 4, a percentage reported as activity, at one dose (the size of the read-out at that dose, not a potency): -15%
Estimate against measurement, compound 4: 8 percentage points above, and the stated range covers the measured number.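

In this assay, chloro in place of bromo on an aromatic carbon gave a number 19.8 percentage points lower from compound 3 to compound 4 (beyond the scatter), so on this second core the change again moves the number towards the stronger effect. The two steps do not differ in size beyond what repeated measurement allows: the same change on two cores in this assay, a number 13.9 percentage points lower (beyond the scatter) from compound 1 to compound 2 and a number 19.8 percentage points lower (beyond the scatter) from compound 3 to compound 4, 5.9 percentage points apart, within the scatter of two such steps

This shows that the shift carries across the two cores shown, but two pairs at one dose in one assay do not fix a general size for it, nor show that it would hold on any other core or at any other place on the ring.

The compounds shown hold only bromo or chloro on that aromatic carbon, so it stays open whether the trend extends to fluoro, or whether a group of another kind, such as methoxy or an amine, would fit it. Also open, going by these compounds, is how a longer chain in place of the two methyl groups would affect the number, and whether the halogen step would persist on such compounds.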